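Swapping the trifluoromethoxy group of compound 3 for ethylsulfonyl

A few compounds are considered here, and "the series" means these few. Any claim that something is new, unique, unknown or untested is made for them only; others in the source may bear on it.

Measured compounds:
compound 1 `Cc1ccc2ccc(-c3cc(F)cc(C#N)c3)cc2n1`: 0.8 nM
compound 2 `Cc1ccc2ccc(-c3cc(C#N)cc(C#N)c3)cc2n1`: 2 nM
compound 3 `Cc1ccc2ccc(-c3cc(C#N)cc(OC(F)(F)F)c3)cc2n1`: 75 nM

In a functional assay on CHO cells for inhibition of metabotropic glutamate receptor 5 (Rattus norvegicus), read by FLIPR and calcium flux (a higher number here means a weaker inhibitor, a lower number a stronger inhibitor), compound 3 gives the highest number of the three measured. The two steps leading to it, a 94-fold higher number from compound 1 to compound 3 (1.97 log units; beyond the scatter) and a 38-fold higher number from compound 2 to compound 3 (1.57 log units; beyond the scatter), were both large. Compound 4 `CCS(=O)(=O)c1cc(C#N)cc(-c2ccc3ccc(C)nc3c2)c1` differs from compound 3 by ethylsulfonyl in place of trifluoromethoxy on an aromatic carbon. No measured step involves ethylsulfonyl, so nothing shown tells how this change will act; the only hint is that compound 3 already sits far above compound 1 and compound 2, and a further group of similar size is being tried at the same place. Compound 4 is therefore expected to stay near compound 3, with a 1.5-fold lower number from compound 3 to compound 4 (0.18 log units; within the scatter) expected to be small, and an estimate of 50 nM (8 nM to 300 nM).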

Compound 4, half-maximal inhibitory concentration: 1090 nM
The estimate for compound 4 lay 22-fold (1.34 log units) below the measured number, outside the stated range (above it).
By their numbers in this assay, from the lowest: compound 1; then compound 2; then compound 3; then compound 4.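

In this assay, ethylsulfonyl at this place, meta to a cyano group, gives the weakest inhibitor of the four: a 15-fold higher number from compound 3 to compound 4 (1.16 log units; beyond the scatter), a 550-fold higher number from compound 2 to compound 4 (2.74 log units; beyond the scatter) and a 1400-fold higher number from compound 1 to compound 4 (3.13 log units; beyond the scatter). Trifluoromethoxy and ethylsulfonyl have the same count of heavy atoms, yet their numbers differ clearly, so that count alone does not set the result here. Across these compounds the number rises in the order fluoro, cyano, trifluoromethoxy, ethylsulfonyl.

Nothing available explains the loss seen with ethylsulfonyl. From the compounds shown here alone, whether a shorter methylsulfonyl, a chlorine or an amine at this place would bring the number back towards that of compound 1 remains open.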